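This account rests on a few compounds, and the source may have more. Where it says the series, first, only, none or still open, it means among the compounds named here.

Measured compounds:
- compound 1, `COc1ccc(C2N(C(=O)COc3cccc4cccnc34)N=C(c3ccc(Br)cc3)C2(C)C)cc1`: "not determined" (no result reported)
- compound 2, `Cc1ccc(C2N(C(=O)COc3cccc4cccnc34)N=C(c3ccc(Cl)cc3)C2(C)C)cc1`: > 100000 nM
- compound 3, `Cc1ccc(C2N(C(=O)COc3cccc4cccnc34)N=C(c3ccccc3)C2(C)C)cc1`: "not determined" (no result reported)

Working notes on the series. In an ADME assay on MCF7 cells (Homo sapiens) for cytotoxicity, read by MTT assay, with a stated time of 48 h (a lower number here means a stronger inhibitor, a higher number a weaker inhibitor), compound 2 gives > 100000 nM, which is a limit of the assay and not a number. For the measured compounds named here, for compound 1 and compound 3 the assay returns no value at all, so compound 3 has no place on a numerical scale: of the three entries, one further is a limit and one further is without a number, and no pair of measured compounds that differ in one place exists in this set.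

The step from compound 3 to compound 4, `COc1ccc(C2N(C(=O)COc3cccc4cccnc34)N=C(c3ccccc3)C2(C)C)cc1`, is methoxy in place of methyl on an aromatic carbon. Going by the values given here, no measured step of this kind is available, so the size and direction of the change can only be expected from what the set shows. The only recorded result lies at the limit of > 100000 nM in this assay, at which 1 of the 3 values shown sits, and nothing in the set suggests that any member falls clearly inside the measurable range. The expectation for this assay is therefore no step beyond the scatter, with the likely outcome again being a limit rather than a number.

Compound 4 is expected to give about 100000 nM, with a range from 30000 nM to 300000 nM.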

Compound 4, half-maximal inhibitory concentration: 98300 nM
Estimate against measurement, compound 4: 1.0-fold (0.01 log units) above, within the range that was stated.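

In this assay, for the compounds shown here, compound 4 gives 98300 nM, while compound 3 has no single number to set against it, so no step between compound 3 and compound 4 can be read. The compounds shown leave open what the change from 4-methylphenyl to 4-methoxyphenyl does to the read-out in this assay.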